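Replacing the aryl arm with bromine on a shared amide core

The compounds below may be only part of what the source reports. "The series", "measured", "known", "first", "only" and "open" are said of these compounds alone.

Measured compounds:
compound 1, `COc1ccc(-c2cn(Cc3ccc(F)cc3)c(=O)c(C(=O)NC3CCCCCC3)c2C)cc1`, 1300 nM
compound 2, `COc1ccc(-c2cn(Cc3ccc(F)cc3)c(=O)c(C(=O)NC3CCCCCC3)c2-c2ccccc2)cc1`, > 10000 nM

Going by the values given here, in an ADME assay on cells for inhibition of Fatty-acid amide hydrolase 1 (Homo sapiens), with stated times of 30 min and 15 min (on this read-out higher numbers stand for weaker inhibition and lower numbers for stronger inhibition), compound 1 gives 1300 nM, the only numerical value shown. For compound 2 the result is a limit of the assay, (the limit of > 10000 nM in this assay, at which 1 of the 2 values shown sits). Among the compounds with values here, the one measured step, an at least 7.6-fold higher number from compound 1 to compound 2 (0.88 log units; beyond the scatter), concerns a different change than the one now considered. Compound 3, `Cc1c(Br)cn(Cc2ccc(F)cc2)c(=O)c1C(=O)NC1CCCCCC1`, differs from compound 1 by bromo in place of 4-methoxyphenyl on an aromatic carbon. Within the data shown here, no measured step bears on it directly, so the estimate rests on the loss of the larger group alone. Compound 3 is expected to give 5000 nM, between 1500 nM and 20000 nM, a step of a 3.8-fold higher number from compound 1 to compound 3 (0.59 log units; beyond the scatter).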

Compound 3, half-maximal inhibitory concentration: 2300 nM
Beside the measured number, compound 3's estimate is 2.2-fold (0.34 log units) above it; low and high end bracket the measured number.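

In this assay the step of a 1.8-fold higher number from compound 1 to compound 3 (0.25 log units; within the scatter) shows that this position tolerates the loss of the whole 4-methoxyphenyl group, with its aromatic ring and its hydrogen-bond acceptor. On this read-out a single bromine atom serves there as well as the far larger arm of compound 1. Nothing measured here explains why the two readings stay within the scatter.

Going by these compounds, what remains open is whether a smaller or different group at this carbon, such as chloro, a nitrile or an amine, would hold that level. The compounds shown also leave open whether an unsubstituted carbon there would do the same.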